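The compounds below may be only part of what the source reports. "The series", "measured", "known", "first", "only" and "open" are said of these compounds alone.

In an assay on isolated protein for inhibition of Rho-associated protein kinase 2 (Homo sapiens), read by scintillation counting, radiometric assay and 33P incorporation, with a stated time of 40 min, in the presence of a further agent that is not named here (a higher number here means a weaker inhibitor, a lower number a stronger inhibitor), the measured compounds read:

Compound 1 `CCCc1ccc(C(=O)Nc2cccc(NC(=O)COc3ccc4c(=O)ccoc4c3)c2)cc1`: 14 nM
Compound 2 `CC(C)(C)c1ccc(C(=O)Nc2cccc(NC(=O)COc3ccc4c(=O)ccoc4c3)c2)cc1`: 34 nM
Compound 3 `O=C(COc1ccc2c(=O)ccoc2c1)Nc1cccc(NC(=O)c2ccc(Br)cc2)c1`: 49 nM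

Compound 3 stands at the highest of the three numbers. The step of a 3.5-fold higher number from compound 1 to compound 3 (0.54 log units; beyond the scatter) lies beyond the scatter, whereas the step of a 1.4-fold higher number from compound 2 to compound 3 (0.16 log units; within the scatter) lies within it, so compound 3 and compound 2 cannot be told apart on these numbers.

Compound 4 `O=C(COc1ccc2c(=O)ccoc2c1)Nc1cccc(NC(=O)c2ccc(OC(F)(F)F)cc2)c1` differs from compound 3 in one place: trifluoromethoxy in place of bromo on an aromatic carbon.

All three measured steps exchange the group on this same aromatic carbon of the shared core. Two of them, a 2.4-fold higher number from compound 1 to compound 2 (0.39 log units; beyond the scatter) and a 3.5-fold higher number from compound 1 to compound 3 (0.54 log units; beyond the scatter), are modest and beyond the scatter; the third, a 1.4-fold higher number from compound 2 to compound 3 (0.16 log units; within the scatter), is within it. None of them involves trifluoromethoxy, so the expectation rests only on the narrow spread those exchanges produced. A step of about a 1.1-fold lower number from compound 3 to compound 4 (0.04 log units; within the scatter) is therefore expected, which is not beyond the scatter in either direction. Compound 4 is estimated to give 45 nM, with a range from 18 nM to 120 nM.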

Compound 4, half-maximal inhibitory concentration: 77 nM
For compound 4 the middle estimate is 1.7-fold (0.23 log units) below the measured one; low and high end bracket the measured number.
By their numbers in this assay, from the lowest: compound 1; then compounds 2, 3 and 4 (each within the scatter of the next, the first and the last beyond it).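

Taking the group at this position from one heavy atom to five, and adding a hydrogen-bond acceptor, gives a 1.6-fold higher number from compound 3 to compound 4 (0.20 log units; within the scatter), so trifluoromethoxy and bromo cannot be told apart in this assay. Unlike bromo, trifluoromethoxy does separate from tert-butyl, with a 2.3-fold higher number from compound 2 to compound 4 (0.36 log units; beyond the scatter), while the exchange against propyl gives a 5.5-fold higher number from compound 1 to compound 4 (0.74 log units; beyond the scatter), leaving compound 1 the most potent of the four. Nothing given here bears on why the numbers fall this way.

The compounds shown leave open whether a longer chain such as butyl, or an amine or a carboxylic acid, on this aromatic carbon would give a number apart from that of compound 1. They also leave open how plain hydrogen would read there.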